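The source may report more compounds than this note shows. Statements on the series, on what has been measured and on what is new or still open speak of the compounds shown alone.

Compound 1 `CC(C)(C)OC(=O)N1CCC[C@@H]1C(=O)N1CCC(NS(=O)(=O)c2cc(S(=O)(=O)c3ccccc3)ccc2C(F)(F)F)CC1` — 120 nM
Compound 2 `CC(C)(C)OC(=O)N1C(=O)CC[C@H]1C(=O)N1CCC(NS(=O)(=O)c2cc(S(=O)(=O)c3ccccc3)ccc2C(F)(F)F)CC1` — 130 nM
Compound 3 `O=C1CC[C@@H](C(=O)N2CCC(NS(=O)(=O)c3cc(S(=O)(=O)c4ccccc4)ccc3C(F)(F)F)CC2)N1` — 90 nM

In an assay on isolated protein for binding affinity to secreted frizzled-related protein 1 (Homo sapiens), read by fluorescence (on this read-out lower numbers stand for stronger inhibition and higher numbers for weaker inhibition), compound 3 gives the lowest of the three numbers shown, yet the steps of a 1.3-fold lower number from compound 1 to compound 3 (0.12 log units; within the scatter) and a 1.4-fold lower number from compound 2 to compound 3 (0.16 log units; within the scatter) both lie within the scatter, so the three compounds cannot be told apart on these measurements. Compound 4 `CN(C)CC(=O)N1CCC[C@H]1C(=O)N1CCC(NS(=O)(=O)c2cc(S(=O)(=O)c3ccccc3)ccc2C(F)(F)F)CC1` differs from compound 3 by 1-(((dimethylamino)methyl)carbonyl)pyrrolidin-2-yl in place of 5-oxopyrrolidin-2-yl on a carbonyl carbon. Both measured steps also changed the group on a carbonyl carbon, and neither moved the number beyond the scatter; the step to compound 4 exchanges more atoms, but the data give no ground for expecting a shift beyond the scatter in this assay. The estimate for compound 4 is 130 nM, with a range from 60 nM to 280 nM. This estimate means an expected step of a 1.4-fold higher number from compound 3 to compound 4 (0.16 log units; within the scatter).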

Compound 4, half-maximal inhibitory concentration: 90 nM
Compound 4: middle estimate off by 1.4-fold (0.16 log units), on the high side; the measured number falls inside the stated range.
By their numbers in this assay, from the lowest: compounds 3, 4, 1 and 2 (each within the scatter of the next).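

In this assay, the new result gives no change at the digits printed from compound 3 to compound 4 (within the scatter) and a 1.3-fold lower number from compound 1 to compound 4 (0.12 log units; within the scatter), both within the scatter. Among these compounds, on this carbonyl carbon, then, the much larger 1-(((dimethylamino)methyl)carbonyl)pyrrolidin-2-yl, which carries a dimethylamino group and no hydrogen-bond donors, leaves the number indistinguishable from those of the earlier groups, a wider swap than the earlier steps tested. Nothing available explains this result. Still open, from the compounds shown here alone, is whether a carboxylic acid or a longer chain on this pyrrolidine nitrogen would move the number beyond the scatter. Also open, going by these compounds, is what a plain pyrrolidin-2-yl, with only a hydrogen on that nitrogen, would give.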